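This account rests on a few compounds, and the source may have more. Where it says the series, first, only, none or still open, it means among the compounds named here.

Going by the values given here, compound 1 `CCc1ccc(-c2nc3c(c(C)nn3-c3ccccc3)c(-c3ccccc3[N+](=O)[O-])c2C#N)cc1` gives 1200 nM in a physicochemical assay for solubility, read by spectrophotometry, in phosphate buffer, with a stated time of 18 h, at pH 7.4 (a lower number here means a less soluble compound, a higher number a more soluble compound), the lowest of the three numbers measured so far. Compound 2 `CCc1ccc(-c2nc3c(c(C)nn3-c3ccccc3)c(-c3ccccc3I)c2C#N)cc1` gives 8500 nM in this assay, and compound 3 `CCc1ccc(-c2nc3c(c(C)nn3-c3ccccc3)c(-c3ccccc3C)c2C#N)cc1` gives 6000 nM in this assay. Compound 4 `CCc1ccc(-c2nc3c(c(C)nn3-c3ccccc3)c(-c3ccccc3C(=O)OC)c2C#N)cc1` differs from compound 1 in one place: methoxycarbonyl in place of nitro on an aromatic carbon. Among the compounds with values here, no measured step swaps nitro for methoxycarbonyl, so the nearest guides are the other replacements of nitro on the same aromatic carbon: a 7.1-fold higher number from compound 1 to compound 2 (0.85 log units; beyond the scatter) and a 5.0-fold higher number from compound 1 to compound 3 (0.70 log units; beyond the scatter). Both are modest rises beyond the scatter, while a 1.4-fold lower number from compound 2 to compound 3 (0.15 log units; within the scatter) shows the two replacing groups landing close together. A rise of similar size is therefore expected in this assay for compound 4, estimated as a 3.3-fold higher number from compound 1 to compound 4 (0.52 log units; beyond the scatter). Compound 4 is expected to give 4000 nM in this assay, with a range of 1500 nM to 10000 nM.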

Compound 4, solubility: 17000 nM
For compound 4 the middle estimate is 4.3-fold (0.63 log units) below the measured one; measured number above the stated range.
By their numbers in this assay, from the lowest: compound 1; then compounds 3, 2 and 4 (each within the scatter of the next, the first and the last beyond it).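

In this assay leaving nitro for methoxycarbonyl gives a 14-fold higher number from compound 1 to compound 4 (1.15 log units; beyond the scatter) and so reaches a large step on this aromatic carbon, where the earlier replacements of nitro stayed modest. The replacing groups also separate: a 2.8-fold higher number from compound 3 to compound 4 (0.45 log units; beyond the scatter) lies beyond the scatter while a 2.0-fold higher number from compound 2 to compound 4 (0.30 log units; within the scatter) lies within it, so methoxycarbonyl and methyl are not interchangeable here. No evidence at hand bears on this result.

Left open is whether a carboxylic acid or an amide on the same carbon would hold a number near that of compound 4. Also open, going by these compounds, is how an amine would read there.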